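Chloro substitution on two pyrazole sulfonamide cores

A few compounds are considered here, and "the series" means these few. Any claim that something is new, unique, unknown or untested is made for them only; others in the source may bear on it.

Compound 1 `COc1ccc(OC)c(-c2cc(-c3ccccc3)nn2-c2ccc(S(=O)(=O)NC(C)=O)cc2)c1` and compound 2 `COc1ccc(OC)c(-c2cc(-c3ccc(Cl)cc3)nn2-c2ccc(S(=O)(=O)NC(C)=O)cc2)c1` share one core and differ by chloro in place of hydrogen on an aromatic carbon. In a functional assay on cells (Cancer cell lines, Homo sapiens) for cytotoxicity, read by sulforhodamine B assay, with a stated time of 48 h (on this read-out lower numbers stand for stronger inhibition of growth and higher numbers for weaker inhibition of growth), compound 1 gives 13300 nM, and compound 2 gives 17700 nM; the step of a 1.3-fold higher number from compound 1 to compound 2 (0.12 log units; within the scatter) is small. Compound 3 `NS(=O)(=O)c1ccc(-n2nc(-c3ccccc3)cc2-c2cc(O)ccc2O)cc1` carries a different core; how the two cores differ is not broken down here. In this assay compound 3 gives 88100 nM, a higher number than either compound 1 or compound 2. Compound 4 `NS(=O)(=O)c1ccc(-n2nc(-c3ccc(Cl)cc3)cc2-c2cc(O)ccc2O)cc1` differs from compound 3 by chloro in place of hydrogen on an aromatic carbon, the same change seen between compound 1 and compound 2. Because the earlier step of a 1.3-fold higher number from compound 1 to compound 2 (0.12 log units; within the scatter) stayed within the scatter, the step from compound 3 to compound 4 is expected to be of similar size, a 1.2-fold higher number from compound 3 to compound 4 (0.08 log units; within the scatter). Compound 4 is therefore estimated at 105000 nM, likely between 50000 nM and 220000 nM.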

Compound 4, concentration for 50% growth inhibition: 12000 nM
Compound 4: the middle estimate sits 8.8-fold (0.94 log units) above what was measured; measured number below the stated range.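

The change from phenyl to 4-chlorophenyl brings a 7.3-fold lower number from compound 3 to compound 4 (0.87 log units; beyond the scatter) in this assay. In this series, the size and direction of the step therefore depended on the core, and the result on one core did not carry over to the other: the same change on two cores in this assay, a 1.3-fold higher number (0.12 log units; within the scatter) from compound 1 to compound 2 and a 7.3-fold lower number (0.87 log units; beyond the scatter) from compound 3 to compound 4, 9.8-fold (0.99 log units) apart, beyond the scatter of two such steps. This rests on one pair of steps and does not show which feature of the two cores lies behind the gap, or whether it would recur on a third core.

The compounds shown leave open how a bromo, a methoxy or an amine in the same place would behave on either core. They also leave open whether such groups would follow compound 2 or compound 4.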